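The source may report more compounds than this note shows. Statements on the series, on what has been measured and on what is new or still open speak of the compounds shown alone.

Measured compounds:
- Compound 1 `C=C1CC[C@@H]2[C@](C)(CO[Si](C(C)C)(C(C)C)C(C)C)[C@H](OC(C)=O)CC[C@@]2(C)[C@@H]1C/C=C1/C(=O)OC[C@H]1OC(C)=O`: 14 uM
- Compound 2 `C=C1CC[C@@H]2[C@](C)(CO)[C@H](OC(C)=O)CC[C@@]2(C)[C@@H]1C/C=C1/C(=O)OC[C@H]1O`: 26.4 uM
- Compound 3 `C=C1CC[C@@H]2[C@](C)(CO)[C@H](OC(C)=O)CC[C@@]2(C)[C@@H]1C/C=C1/C(=O)OC[C@H]1OC(C)=O`: 11 uM

All three were tested in a functional assay on MCF7 cells (Homo sapiens) for cytotoxicity, read by sulforhodamine B assay (on this read-out higher numbers stand for an effect only at larger amounts of compound and lower numbers for an effect already at smaller amounts), and all three share the same core. Compound 3 gives 11 uM, the lowest of the three numbers. Its nearest neighbour is compound 1; the step of a 1.3-fold lower number from compound 1 to compound 3 (0.10 log units; within the scatter) is too small to count. The step of a 2.4-fold lower number from compound 2 to compound 3 (0.38 log units; beyond the scatter) is larger and does lie beyond the scatter, so compound 2 is set apart from compound 3 by that change alone.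

Compound 4 `C=C1CC[C@@H]2[C@](C)(CO[Si](C)(C)C(C)(C)C)[C@H](OC(C)=O)CC[C@@]2(C)[C@@H]1C/C=C1/C(=O)OC[C@H]1OC(C)=O` is not yet measured. It differs from compound 3 by a group of 7 heavy atoms (6 carbon, 1 silicon; no ring) in place of a hydrogen atom, on an oxygen on a saturated carbon. Among the measured compounds shown here, the step that bears on this is the one between compound 1 and compound 3, where a larger group of the same kind at the same oxygen made no difference beyond the scatter. On that basis the step of a 1.2-fold higher number from compound 3 to compound 4 (0.07 log units; within the scatter) is expected to be small, with no direction that can be trusted. The estimate for compound 4 in this assay is 13 uM, in a range from 6 uM to 28 uM.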

Compound 4, concentration for half-maximal effect: 2.84 uM
Compound 4: middle estimate off by 4.6-fold (0.66 log units), on the high side; the measured number lies below the stated range.
By their numbers in this assay, from the lowest: compound 4; then compounds 3, 1 and 2 (each within the scatter of the next, the first and the last beyond it).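

In this assay, this oxygen on a saturated carbon turns out not to be indifferent to what it carries: the group of 7 heavy atoms (6 carbon, 1 silicon) gives a 3.9-fold lower number from compound 3 to compound 4 (0.59 log units; beyond the scatter), although the larger silicon group had left no change beyond the scatter. The comparison between the two silicon groups, a 4.9-fold lower number from compound 1 to compound 4 (0.69 log units; beyond the scatter), shows that the identity of the group matters, not just the presence of one, and the number does not follow heavy-atom count in a single direction from hydrogen through 7 to 10 heavy atoms. Nothing available explains this difference.

As far as these compounds go, whether the lower number is special to this one silicon group stays open. An acetyl or a methyl on the same oxygen would show whether groups without silicon can do the same.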